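This account rests on a few compounds, and the source may have more. Where it says the series, first, only, none or still open, it means among the compounds named here.

Measured compounds:
- compound 1, `N[C@]1(C(=O)O)[C@H]2[C@@H](C[C@H]1OCc1cccc(Cl)c1)[C@]2(F)C(=O)O`: 3.28 nM in an assay on CHO cells for binding affinity to metabotropic glutamate receptor 2 (Rattus norvegicus); on this read-out higher numbers stand for weaker inhibition and lower numbers for stronger inhibition
- compound 2, `N#Cc1cccc(CO[C@@H]2C[C@@H]3[C@H]([C@]2(N)C(=O)O)[C@@]3(F)C(=O)O)c1`: 2.94 nM in this assay

Among the compounds with values here, compound 2 holds the lowest of the two numbers in this assay, but its only neighbour is compound 1, and the step of a 1.1-fold lower number from compound 1 to compound 2 (0.05 log units; within the scatter) lies within the scatter, so the two compounds cannot be ranked against each other.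

Compound 3, `N[C@]1(C(=O)O)[C@H]2[C@@H](C[C@H]1OCc1cccc(-c3ccccc3)c1)[C@]2(F)C(=O)O`, has not yet been measured in this assay. It differs from compound 2 in one place: phenyl in place of cyano on an aromatic carbon.

Within the data shown here, only one measured step bears on this change, the exchange of chloro for cyano on the same aromatic carbon from compound 1 to compound 2, and that step was within the scatter. It shows that this position of the benzyloxy group tolerates two small groups without a shift in the number, but it says nothing about a phenyl, which is a far larger group than either. The expectation therefore rests more on the size of the change than on a measured trend: a step of moderate size, more likely toward a higher number than a lower one, is expected, a 2.4-fold higher number from compound 2 to compound 3 (0.38 log units; beyond the scatter).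

Compound 3 is estimated at 7 nM in this assay, with a range from 1.5 nM to 30 nM.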

Compound 3, inhibition constant: 9.34 nM
Compound 3: the middle estimate sits 1.3-fold (0.13 log units) below what was measured, within the range that was stated.
By their numbers in this assay, from the lowest: compounds 2 and 1 (each within the scatter of the next); then compound 3.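

Notes on the aromatic carbon of the benzyloxy group in this assay: the phenyl change gives a 3.2-fold higher number from compound 2 to compound 3 (0.50 log units; beyond the scatter) and, against the chloro analogue, a 2.8-fold higher number from compound 1 to compound 3 (0.45 log units; beyond the scatter) and so provides the first steps at this position that lie beyond the scatter, whereas the exchange of chloro for cyano did not. The position is therefore not indifferent to every group placed there, although the shift remains modest for a phenyl of 6 heavy atoms and one six-membered aromatic ring entering where cyano has 2 heavy atoms and no ring. No measurement shown here explains the shift.

With only chloro, cyano and phenyl compared at this carbon, the series cannot separate the contribution of the aromatic ring from that of the added atoms, and a cyclohexyl or a benzyl group would be needed to address that question. On these data alone, how an amine, a carboxylic acid or a longer alkyl chain at the same carbon would compare in this assay also remains open, as does whether a phenyl keeps the same modest step on a different aromatic carbon of the benzyloxy group.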